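A Nitrile Gives Way to a Tertiary Alcohol

The source may hold more compounds than are shown below. What is called first, only, known or untested is meant among the compounds shown, and "the series" means these compounds.

Compound 1, `C=CCc1cc(C(C)=O)c(O)cc1OCCCCCCCC#N`, is the reference point in this set. In an assay on isolated protein for inhibition of leukotriene B4 receptor 1 (Homo sapiens), tested at 10 uM (a lower number here means less inhibition, a higher number more inhibition at the concentration tested (going by the name of the read-out)), compound 1 gives 88%, the highest of the three numbers recorded. Compound 2, `CCc1cc(C(C)=O)c(O)cc1OCCCCCCCC(C)(C)C#N`, comes nearest; in this assay compound 2 gives 66%, a number that lies beyond the usual scatter below compound 1. Compound 3, `CC(=O)c1cc(C(C)(C)C)c(OCCCCCC(C)(C)C#N)cc1O`, stands furthest away: in this assay compound 3 gives 1%, far beyond the scatter below compound 1. No two of these compounds differ in only one place, so the three values can only be read side by side and no single change can be given its own size.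

Compound 4, `C=CCc1cc(C(C)=O)c(O)cc1OCCCCCC(C)(C)O`, has not yet been measured. It differs from compound 1 in one place: 1-hydroxy-1-methylethyl in place of 2-cyanoethyl on a saturated chain carbon, five bonds along the chain from an oxygen on an aromatic ring. The nitrile at the chain end is replaced by a group that carries a hydrogen-bond donor. Among the compounds with values here, with no measured pair to lean on, the step is expected to lower the number, probably beyond the scatter, and the estimated step in this assay is a number 23 percentage points lower from compound 1 to compound 4 (beyond the scatter). For compound 4 the expected value in this assay is 65%, with a range from 35% to 88%.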

Compound 4, a percentage reported as inhibition, at one concentration (the size of the read-out at that concentration, not a potency): 98%
The estimate for compound 4 lay 33 percentage points below the measured number; the whole stated range lies below it.
By their numbers in this assay, from the lowest: compound 3; then compound 2; then compounds 1 and 4 (each within the scatter of the next).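

In this assay, putting 1-hydroxy-1-methylethyl in place of 2-cyanoethyl on a saturated chain carbon, five bonds along the chain from an oxygen on an aromatic ring, amounts to a number 10 percentage points higher from compound 1 to compound 4 (within the scatter). The nitrile is therefore not needed at this place for the number to stay this high on the core of compound 1, and a chain end that carries a hydrogen-bond donor is accepted there. Nothing available here explains this result.

On these data alone, because the read-out comes from one concentration and not from a potency, any difference between these two compounds at other concentrations remains open. As far as these compounds go, it also remains open how a carboxylic acid or a primary amide at the same chain end would read, and whether a longer chain would keep the number at this level.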